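A few compounds are considered here, and "the series" means these few. Any claim that something is new, unique, unknown or untested is made for them only; others in the source may bear on it.

Measured compounds:
Compound 1, `CC(=O)Nc1cccc2c1CCCC2c1c[nH]cn1`: 4.84
Compound 2, `COc1ccc(NS(C)(=O)=O)c2c1C(c1c[nH]cn1)CCC2`: 4.74

In a functional assay on spleen for agonist activity at Alpha-1B adrenergic receptor (Rattus norvegicus) (on this read-out lower numbers stand for lower potency and higher numbers for higher potency (the scale is a negative logarithm)), compound 1 gives 4.84, while compound 2 gives 4.74. The two numbers lie within the scatter of each other, so neither compound can be called the more potent; compound 1 merely holds the higher of the two numbers. The unmeasured compound 3, `CN(c1cccc2c1CCCC2c1c[nH]cn1)S(C)(=O)=O`, is reached from compound 1 by a single change: methyl(methylsulfonyl)amino in place of acetamido on an aromatic carbon. Going by the values given here, no measured pair of compounds isolates this change, so there is no step of the same kind to lean on. With the two known values close together, the step from compound 1 to compound 3 is expected to be small, in either direction, and not beyond the scatter: a number 0.14 log units lower from compound 1 to compound 3 (within the scatter). Compound 3 is therefore estimated at 4.7, with a likely range from 4.2 to 5.2.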

Compound 3, negative logarithm of the half-maximal effective concentration: 5.65
Estimate against measurement, compound 3: 0.95 log units below; measured number above the stated range.
By their numbers in this assay, from the lowest: compounds 2 and 1 (each within the scatter of the next); then compound 3.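

In this assay, the aromatic carbon that carries the group in compound 1 turns out to be sensitive to what sits on it: methyl(methylsulfonyl)amino in place of acetamido gives a number 0.81 log units higher from compound 1 to compound 3 (beyond the scatter), and this step lies beyond the scatter. Compounds 1 and 2 could not show this, since they differ in more than one place and their numbers lie within the scatter. The swap also changes several counted features at once, going from 4 heavy atoms to 6 and from 1 hydrogen-bond donor to 0, so this single step cannot assign the gain to any one of them.

Going by these compounds, it remains open how a plain amine or a longer chain such as ethylsulfonyl would read at this carbon. Nothing measured here accounts for the rise.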